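A Methylpyrimidine on the Sulfonamide Nitrogen

The source may hold more compounds than are shown below. What is called first, only, known or untested is meant among the compounds shown, and "the series" means these compounds.

Three compounds built on a shared core were tested in a functional assay on HT-1080 cells (Homo sapiens) for antiproliferative activity, read by sulforhodamine B assay, with a stated time of 48 h; a lower number here means a stronger inhibitor, a higher number a weaker inhibitor. Compound 1 `Nc1ccc(S(=O)(=O)Nc2ccnc3cc(C(F)(F)F)ccc23)cc1` gives 29600 nM. Compound 2 `N=C(N)NS(=O)(=O)c1ccc(N/C(S)=N\c2ccnc3cc(C(F)(F)F)ccc23)cc1` gives 24300 nM, the lowest of the three numbers, yet within the scatter of both others. Compound 3 `O=S(=O)(Nc1ncccn1)c1ccc(N/C(S)=N\c2ccnc3cc(C(F)(F)F)ccc23)cc1` gives 29100 nM. Going by the values given here, the only measured step that bears on the question, a ring replacing the same group on the sulfonamide nitrogen, was a 1.2-fold higher number from compound 2 to compound 3 (0.08 log units; within the scatter). Compound 4 `Cc1ccnc(NS(=O)(=O)c2ccc(N/C(S)=N\c3ccnc4cc(C(F)(F)F)ccc34)cc2)n1` differs from compound 2 by a group of 7 heavy atoms (5 carbon, 2 nitrogen; one six-membered aromatic ring with 2 hetero atoms) in place of a group of 3 heavy atoms (1 carbon, 2 nitrogen; no ring), on a sulfonamide nitrogen. Given that precedent, no step beyond the scatter is expected in this assay. Compound 4 is therefore estimated at 27000 nM, with a range from 12000 nM to 60000 nM. That estimate corresponds to an expected step of a 1.1-fold higher number from compound 2 to compound 4 (0.05 log units; within the scatter).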

Compound 4, half-maximal inhibitory concentration: 28700 nM
The estimate for compound 4 lay 1.1-fold (0.03 log units) below the measured number; measured number inside the range.
By their numbers in this assay, from the lowest: compounds 2, 4, 3 and 1 (each within the scatter of the next).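

In this assay, the 4-methylpyrimidin-2-yl group on the sulfonamide nitrogen gave a 1.2-fold higher number from compound 2 to compound 4 (0.07 log units; within the scatter), so this second ring-bearing group also left the number within the scatter. Methyl in place of hydrogen on an aromatic carbon gave a 1.0-fold lower number from compound 3 to compound 4 (0.01 log units; within the scatter), so that addition produced no readable change. No measurement on hand offers an explanation for these results.

Going by these compounds, whether an amine or a carboxylic acid in place of that methyl would shift the number remains open. So does whether a longer chain there would produce a step beyond the scatter.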